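The compounds below may be only part of what the source reports. "The series", "measured", "known", "first", "only" and "open" are said of these compounds alone.

Working notes on the series. In an ADME assay on microsomes from liver (Rattus norvegicus) for metabolic stability, read by LC-MS, with a stated time of 10 min, tested at 0.5 uM (a lower number here means that less of the compound is left, a higher number that more of the compound is left), compound 2 `c1ccc2c(c1)CN[C@@H](CN(CCC1CCNCC1)[C@H]1CCCc3cccnc31)C2` gives 17%. That is level, within the scatter, with compound 3 `c1cnc2c(c1)CCC[C@@H]2N(CCCN1CCNCC1)Cc1nc2ccccc2s1` at 21%, and far from compound 1 `c1ccc2c(c1)CN[C@H](CN(CCCN1CCNCC1)[C@H]1CCCc3cccnc31)C2` at 88%.

Compound 4 `CN1CCN(CCCN(C[C@H]2Cc3ccccc3CN2)[C@H]2CCCc3cccnc32)CC1` carries (4-methylpiperazin-1-yl)methyl in place of piperidin-4-yl on a saturated chain carbon, two bonds along the chain from an amine nitrogen.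

Going by the values given here, no measured step isolates this change. Among the compounds with values here, the only step available, a number 67 percentage points lower from compound 1 to compound 3 (beyond the scatter), is large, but it swaps 1,3-benzothiazol-2-yl for 1,2,3,4-tetrahydroisoquinolin-3-yl at a different place. It therefore bears on the change only indirectly: compound 1 and compound 3 share a chain that lacks only the methyl of the 3-(4-methylpiperazin-1-yl)propyl in compound 4, yet their numbers lie far apart in this assay. That chain alone thus does not fix the read-out. Compound 1 at 88% shows that a high number is possible with it, so some upward movement is expected, though with little confidence.

The estimated step is a number 23 percentage points higher from compound 2 to compound 4 (beyond the scatter), an expected moderate rise with wide uncertainty. For compound 4 the expected value is 40%, with an estimated range from 15% to 75%.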

Compound 4, percent of the compound remaining: 10%
Compound 4: the middle estimate sits 30 percentage points above what was measured; measured number below the stated range.
By their numbers in this assay, from the lowest: compounds 4, 2 and 3 (each within the scatter of the next, the first and the last beyond it); then compound 1.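

Going by these compounds alone, this is the first measured step at this position: in this assay, a number 7 percentage points lower from compound 2 to compound 4 (within the scatter). On this core, therefore, exchanging piperidin-4-yl for (4-methylpiperazin-1-yl)methyl, which can equally be read as 2-(piperidin-4-yl)ethyl to 3-(4-methylpiperazin-1-yl)propyl, leaves the read-out level, even though the entering group has two more heavy atoms, a second ring nitrogen and no hydrogen-bond donor. Nothing available explains this result or the gap to the high number of compound 1.

Going by these compounds, the pair covers only these two end groups, so it remains open whether a morpholin-4-yl ring or an acetyl group on the outer piperazine nitrogen at the end of the same chain would stay level with compound 2 and compound 4 or move clear of them. Within the data shown here, no single-place step connects compound 4 to compound 1 at 88%, so what separates that number from this pair also remains open.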